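Cytotoxicity notes on a shared-core series

The compounds below may be only part of what the source reports. "The series", "measured", "known", "first", "only" and "open" are said of these compounds alone.

compound 1 `CCCCSc1nc(N)nc2c1ncn2/C=C1/CC1(CO)CO`: > 20000 nM
compound 2 `Nc1nc(NC2CCCCC2)c2ncn(/C=C3/CC3(CO)CO)c2n1`: > 20000 nM
compound 3 `Nc1nc(NC2CCCC2)c2ncn(/C=C3/CC3(CO)CO)c2n1`: 71700 nM

In an ADME assay on BCBL1 cells (Homo sapiens) for cytotoxicity, with a stated time of 7 days (on this read-out lower numbers stand for higher toxicity in this test and higher numbers for lower toxicity in this test), compound 1 gives only a limit, > 20000 nM. Compound 2 likewise reaches only a limit, > 20000 nM. Compound 3 gives a number, 71700 nM. The step that the two limits leave unreadable from compound 1 to compound 2 cannot be sized; the same holds for a step that the limit leaves unreadable from compound 1 to compound 3 and for a step that the limit leaves unreadable from compound 2 to compound 3. Two of the three values sit at the limit of > 20000 nM in this assay, at which 2 of the 3 values shown sit. Compound 2 therefore stands at that limit, with no readable step to either of its neighbours.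

Compound 4 `Nc1nc(SCc2ccccc2)c2ncn(/C=C3/CC3(CO)CO)c2n1` is not yet measured in this assay. It differs from compound 2 as follows: benzylsulfanyl in place of cyclohexylamino on an aromatic carbon. Going by the values given here, none of the measured steps covers a benzylsulfanyl group; the only step touching a sulfanyl chain, a step that the two limits leave unreadable from compound 1 to compound 2, is unreadable in size. No readable step points in any direction, so no step beyond the scatter is expected, and the estimate keeps compound 4 close to the limit where compound 2 sits. Compound 4 is expected at 40000 nM, within a range from 15000 nM to 120000 nM. The step this estimate implies, a step that the limit leaves unreadable from compound 2 to compound 4, is an expectation only, and a limit rather than a number is considered the more likely outcome.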

Compound 4, half-maximal cytotoxic concentration: > 20000 nM
Compound 4: no number, only a limit (the forecaster's own chance of this, stated with the estimate: 60%); the middle value does not contradict the limit.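

In this assay compound 4 gives only a limit, > 20000 nM. Going by these compounds alone, its steps from compound 1, compound 2 and compound 3 cannot be read, so no new step results. Most values shown are limits: the limit of > 20000 nM in this assay, at which 3 of the 4 values shown sit.

The compounds shown leave open whether any group at this place shifts the read-out beyond the scatter.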